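Ester in Place of Phenol on the Anilide Nitrogen

This account rests on a few compounds, and the source may have more. Where it says the series, first, only, none or still open, it means among the compounds named here.

Compound 1 `CONC(=O)[C@@H]1CC=C(CCC=C(C)C)C[C@H]1c1ccccc1` — 2700 nM
Compound 2 `CC(C)=CCCC1=CC[C@@H](C(=O)Nc2ccc(C(=O)O)cc2)[C@H](c2ccccc2)C1` — 2200 nM
Compound 3 `CC(C)=CCCC1=CC[C@@H](C(=O)Nc2ccc(O)cc2)[C@H](c2ccccc2)C1` — > 23000 nM

All three compounds share one core and differ only in the group on the amide-type nitrogen. In an assay on isolated protein for inhibition of Apoptosis regulator Bcl-2 (Homo sapiens), read by fluorescence polarization, with stated times of 5 min and 10 min (on this read-out lower numbers stand for stronger inhibition and higher numbers for weaker inhibition), compound 1 gives 2700 nM and compound 2 gives 2200 nM, a difference of a 1.2-fold lower number from compound 1 to compound 2 (0.09 log units; within the scatter). Compound 3 stands apart: in this assay it yields only a limit, > 23000 nM, so no number is known for it, only a floor, (the limit of > 23000 nM in this assay, at which 1 of the 3 values shown sits). The step of an at least 8.5-fold higher number from compound 1 to compound 3 (0.93 log units; beyond the scatter) and the step of an at least 10-fold higher number from compound 2 to compound 3 (1.01 log units; beyond the scatter) both run beyond the scatter, and both place the hydroxy-bearing compound 3 at the weak end of what is shown.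

Compound 4 `COC(=O)c1ccc(NC(=O)[C@@H]2CC=C(CCC=C(C)C)C[C@H]2c2ccccc2)cc1` has not yet been measured. It differs from compound 3 by methoxycarbonyl in place of hydroxy on an aromatic carbon. Within the data shown here, the closest measured comparison is the step of an at least 10-fold higher number from compound 2 to compound 3 (1.01 log units; beyond the scatter), which shows that a carboxy on that aromatic carbon is tied to a far lower number than a hydroxy; the methoxycarbonyl of compound 4 is a related but uncharged group, for which no step is measured. Compound 4 is therefore expected to improve on compound 3 in this assay by an at least 2.8-fold lower number from compound 3 to compound 4 (0.45 log units; beyond the scatter), yet not necessarily to reach the number of compound 2. The estimated value of compound 4 in this assay is 8000 nM, with a range from 2000 nM to 30000 nM.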

Compound 4, inhibition constant: > 23000 nM
Compound 4 ended at the assay's limit; the forecaster's own chance of this, stated with the estimate: 30%; middle value at least 2.8-fold (0.45 log units) away from the limit.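

In this assay compound 4 yields only a limit, so the methoxycarbonyl group gives no number and leaves compound 4 where compound 3 stands: the limit of > 23000 nM in this assay, at which 2 of the 4 values shown sit. Turning the carboxy into methoxycarbonyl gives an at least 10-fold higher number from compound 2 to compound 4 (1.01 log units; beyond the scatter), so on this aromatic carbon, para to a large group, the free carboxy goes with a measured number while its methyl ester goes with only a limit. Placing the 4-(methoxycarbonyl)phenyl on the amide-type nitrogen in place of methoxy gives an at least 8.5-fold higher number from compound 1 to compound 4 (0.93 log units; beyond the scatter), whereas the 4-carboxyphenyl of compound 2 stays within the scatter of compound 1, so among these compounds an aromatic ring on that nitrogen does not by itself keep the number, and the group on its far carbon decides the outcome.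

Going by these compounds, the step between compound 3 and compound 4 cannot be read, and how far past the limit either compound lies remains unknown. Also open, on these data alone, is what other groups on this aromatic carbon would give, such as an amine, a sulfonic acid or a carboxylic acid on a longer chain, and so whether the carboxy of compound 2 can be replaced at all.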